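Swapping the aryl group on a glucagon receptor antagonist core

A few compounds are considered here, and "the series" means these few. Any claim that something is new, unique, unknown or untested is made for them only; others in the source may bear on it.

Measured compounds:
Compound 1 `C[C@H](c1ccc(C(=O)NCCC(=O)O)cc1)N1C(=O)C(c2cccc(OC(F)(F)F)c2)=N[C@]12CC[C@@H](C(C)(C)C)CC2` gives 840 nM
Compound 2 `CC1(CC[C@H](c2ccc(C(=O)NCc3nn[nH]n3)cc2)N2C(=O)C(c3cc(Cl)cc(Cl)c3)=N[C@]23CC[C@@H](C(C)(C)C)CC3)CC1` gives 100 nM
Compound 3 `CC(C)(C)[C@H]1CC[C@]2(CC1)N=C(c1cccc(Cl)c1)C(=O)N2Cc1ccc(C(=O)NCCC(=O)O)cc1` gives 770 nM

All three were tested in a functional assay on CHO cells for antagonist activity at Glucagon receptor (Homo sapiens), read by cAMP accumulation, with stated times of 30 min and 45 min; a higher number here means a weaker inhibitor, a lower number a stronger inhibitor. Among them compound 1 has the highest number, though compound 3 sits within the usual scatter of it, so the two cannot be told apart. Compound 2, which differs from compound 1 in several places at once, has a number far enough below to count as a real difference.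

Compound 4 `C[C@H](c1ccc(C(=O)NCCC(=O)O)cc1)N1C(=O)C(c2cccc(Cl)c2F)=N[C@]12CC[C@@H](C(C)(C)C)CC2` keeps everything of compound 1 except one group: 3-chloro-2-fluorophenyl in place of 3-(trifluoromethoxy)phenyl on a carbon with a double bond to nitrogen. Among the measured compounds shown here, no pair of measured compounds shows this exact change on its own, so the expected step must be read from the neighbours. Compound 3 carries a 3-chlorophenyl on the same carbon and gives a number within the scatter of compound 1, which suggests that chlorine at that position does not by itself move the read-out much. The extra fluorine in compound 4 is not covered by any measured pair.

On this basis the step in this assay from compound 1 to compound 4 is expected to be small, if anything toward a lower number, estimated at a 1.7-fold lower number from compound 1 to compound 4 (0.23 log units; within the scatter). Compound 4 is therefore expected to give about 500 nM, within a range of 150 nM to 1600 nM.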

Compound 4, half-maximal inhibitory concentration: 630 nM
Compound 4: middle estimate off by 1.3-fold (0.10 log units), on the low side; the measured number falls inside the stated range.
By their numbers in this assay, from the lowest: compound 2; then compounds 4, 3 and 1 (each within the scatter of the next).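

In this assay, placing 3-chloro-2-fluorophenyl in place of 3-(trifluoromethoxy)phenyl on the carbon with a double bond to nitrogen gives a 1.3-fold lower number from compound 1 to compound 4 (0.12 log units; within the scatter), a step within the usual scatter. This is the first change shown at this carbon with the rest of the molecule held fixed, and the two aryl groups cannot be told apart here, although the entering group has fewer heavy atoms and no hydrogen-bond acceptor. Nothing measured here offers an explanation for this result.

From the compounds shown here alone, it remains open whether a pyridine ring, or a phenyl ring bearing an amine or a carboxylic acid, would give a similar number at this carbon. Also open, going by these compounds, is whether this same swap would give a similar step if another part of compound 1 were changed.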